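The source may hold more compounds than are shown below. What is called first, only, known or untested is meant among the compounds shown, and "the series" means these compounds.

The account follows compound 1 `C=C1CCCC(C)(C)C1(O)CC/C(C)=C/CC[C@]1(C)CC[C@@H]([C@@H](C)C(=O)OC)OO1` to compound 4 `C=C1CCCC(C)(C)C1(O)CC/C(C)=C/CC[C@]1(C)CC[C@H]([C@@H](C)C(=O)OC)OO1`, which has not yet been measured. In a functional assay on 786-0 cells (Homo sapiens) for cytotoxicity, read by colony formation (on this read-out lower numbers stand for stronger inhibition of growth and higher numbers for weaker inhibition of growth), compound 1 gives only a limit, > 5000 nM, and not a number. Compound 3 `CC1=C(CC/C(C)=C/CC[C@@]2(C)CC[C@@H]([C@H](C)C(=O)O)OO2)C(C)(C)CCC1` likewise reaches only a limit in this assay, > 5000 nM. Compound 2 `C=C1CCC[C@H]2[C@](C)(CC[C@]3(C)CC[C@H]([C@@H](C)C(=O)O)OO3)[C@@H](C)CC[C@]12C` is the one of the three that gives a number in this assay, 610 nM. For the measured compounds named here, compound 1 therefore stands at the limit of > 5000 nM in this assay, at which 2 of the 3 values shown sit, so nothing separates it from compound 3, and the only number among the three belongs to compound 2.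

Compound 4 differs from compound 1 in a single drawn configuration: the two compounds have the same atoms and bonds; at least one stereo element is drawn with a configuration in one of them and without one in the other: 1 of 5 stereo elements differ; a stereocentre at a saturated ring carbon is drawn S in compound 1 and R in compound 4. Going by the values given here, no measured pair in this set changes configuration alone, so no step of that kind is on record. The expectation for the change from compound 1 to compound 4 is therefore a step of no more than the usual scatter, with compound 4 most likely remaining at the same limit, so a number no higher from compound 1 to compound 4 (the limit leaves the size open) is the expected step. Compound 4 is accordingly estimated at 5000 nM in this assay, within a range from 1500 nM to 20000 nM, and the measurement now awaited will show whether that holds.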

Compound 4, concentration for 50% growth inhibition: > 5000 nM
Compound 4: a limit, no number (the forecaster's own chance of this, stated with the estimate: 70%); the middle value lies on the limit itself.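

In this assay compound 4 gives > 5000 nM, which is a limit and not a number. Compound 1 also gives only a limit, so no step between the two can be read: the limit of > 5000 nM in this assay, at which 3 of the 4 values shown sit. The compounds shown leave open whether the configuration at that saturated ring carbon changes growth inhibition at all.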